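Swapping Hydroxy for Carbamoyl in a Cytotoxicity Series

A few compounds are considered here, and "the series" means these few. Any claim that something is new, unique, unknown or untested is made for them only; others in the source may bear on it.

Going by the values given here, in a functional assay on CLL cells (Homo sapiens) for cytotoxicity, read by MTT assay, with a stated time of 48 h (on this read-out higher numbers stand for an effect only at larger amounts of compound and lower numbers for an effect already at smaller amounts), compound 1 (`C=C(CC)C(=O)c1ccc(OCC(=O)Nc2ccc(/C=C/C(=O)NO)cc2)c(Cl)c1Cl`) gives 2600 nM as its result, while compound 2 (`C=C(CC)C(=O)c1ccc(OCC(=O)Nc2ccc(O)cc2)c(Cl)c1Cl`) gives 6400 nM and so holds the higher of the two numbers measured so far. The next candidate is compound 3 (`C=C(CC)C(=O)c1ccc(OCC(=O)Nc2ccc(C(N)=O)cc2)c(Cl)c1Cl`), and its difference from compound 2 is a single exchange (carbamoyl in place of hydroxy on an aromatic carbon): carbamoyl in place of hydroxy on an aromatic carbon, para to a large group.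

Among the compounds with values here, only one measured step bears on this exchange, since it also replaced the group on that aromatic carbon. Within the data shown here, with a 2.5-fold higher number from compound 1 to compound 2 (0.39 log units; beyond the scatter) as the only guide, and a modest one, a small change is expected in this assay for the new exchange. A slight drift towards a lower number is the best guess, though the data give little basis for a direction. The expected move is a 1.3-fold lower number from compound 2 to compound 3 (0.11 log units; within the scatter) and it should stay within the usual scatter of repeated measurements. The estimate for compound 3 is 5000 nM with 2400 nM to 10000 nM as its expected range.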

Compound 3, half-maximal effective concentration: 3700 nM
Compound 3: middle estimate off by 1.4-fold (0.13 log units), on the high side, within the range that was stated.
By their numbers in this assay, from the lowest: compounds 1, 3 and 2 (each within the scatter of the next, the first and the last beyond it).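

In this assay the exchange at this aromatic carbon gives a 1.7-fold lower number from compound 2 to compound 3 (0.24 log units; within the scatter) and so stays inside the usual noise, even though the entering carbamoyl has 3 heavy atoms and the leaving hydroxy has 1. Carbamoyl in place of the 2-(hydroxycarbamoyl)ethenyl group gives a 1.4-fold higher number from compound 1 to compound 3 (0.15 log units; within the scatter) as its step, which means that a compound without that longer group can still give a number that cannot be told apart from the number of compound 1. Compound 3 therefore sits within the scatter of both neighbours, and only the hydroxy exchange, with a 2.5-fold higher number from compound 1 to compound 2 (0.39 log units; beyond the scatter) as its step, separates two of these compounds, while nothing measured here accounts for this pattern.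

An amine, a carboxylic acid or a simple alkyl chain on this same carbon would show whether this narrow spread also holds for groups of other kinds, or whether some group moves the number clearly away from compound 1. The compounds shown also leave open whether carbamoyl and hydroxy would compare in the same way at another place on the ring.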